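From compound 2 to compound 3: methoxy for chloro

The source may report more compounds than this note shows. Statements on the series, on what has been measured and on what is new or still open speak of the compounds shown alone.

In an ADME assay on HepG2 cells (Homo sapiens) for cytotoxicity, read by MTT assay (a higher number here means a weaker inhibitor, a lower number a stronger inhibitor), compound 1 (`ClC(Cl)(Cl)c1nc(-c2ccccc2)c2ccccc2n1`) gives > 125000 nM, a limit of the assay and not a number. Compound 2 (`Clc1ccc(-c2nc(C(Cl)(Cl)Cl)nc3ccccc23)cc1`) gives > 125000 nM, also only a limit. For the measured compounds named here, the series so far stands at one value: the limit of > 125000 nM in this assay, at which 2 of the 2 values shown sit. Going by the values given here, the one measured step, a step that the two limits leave unreadable from compound 1 to compound 2, is chloro in place of hydrogen on an aromatic carbon.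

Compound 3 (`COc1ccc(-c2nc(C(Cl)(Cl)Cl)nc3ccccc23)cc1`) differs from compound 2 at one place, methoxy in place of chloro on an aromatic carbon. With no readable step to scale from, no change beyond the scatter is expected in this assay, and the expected step is a number no higher from compound 2 to compound 3 (the limit leaves the size open). The estimate for compound 3 is 125000 nM, with a range of 40000 nM to 250000 nM.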

Compound 3, half-maximal inhibitory concentration: 125000 nM
Beside the measured number, compound 3's estimate shows no gap at the digits printed; low and high end bracket the measured number.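

In this assay, for the compounds shown here, compound 3 gives 125000 nM as a number and not a limit, so methoxy in place of chloro on this aromatic carbon, para to a large group, yields the first readable value of the series, a number no higher from compound 2 to compound 3 (the limit leaves the size open). Methoxy in place of hydrogen at this place gives a number no higher from compound 1 to compound 3 (the limit leaves the size open). The size of these two steps cannot be read, and the series still stands at one level: the limit of > 125000 nM in this assay, at which 2 of the 3 values shown sit.

Going by these compounds, whether any group at this place brings the value clearly away from that level stays open. An amine or a carboxylic acid here would test this.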